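A few compounds are considered here, and "the series" means these few. Any claim that something is new, unique, unknown or untested is made for them only; others in the source may bear on it.

Working notes on the series in a functional assay on NCI-H460 cells (Homo sapiens) for inhibition, read by CCK-8 assay, with a stated time of 72 h, tested at 10 uM; on this read-out lower numbers stand for less inhibition of growth and higher numbers for more inhibition of growth at the one concentration tested.

Three members of the series carry a measured number. Compound 1, `CN(C)C(=O)c1cc2cnc(Nc3ccc(NC(=O)C4(C(=O)Nc5ccc(F)cc5)CC4)cc3F)nc2n1C1CCCC1`, gives 53% in this assay. Compound 2, `CN(C)C(=O)c1cc2cnc(Nc3ccc(NC(=O)C4(C(=O)Nc5ccc(Br)cc5)CC4)cc3)nc2n1C1CCCC1`, gives 96.4% in this assay. Compound 3, `CN(C)C(=O)c1cc2cnc(Nc3ccc(N)cn3)nc2n1C1CCCC1`, gives 62% in this assay. Of the three numbers compound 2 stands highest: its nearest neighbour is compound 3, whose number lies lower by a margin beyond the usual scatter, and the furthest is compound 1, whose number lies lower by a still wider margin, also beyond the scatter. No pair among these three differs in one place only, so no single-point step between measured compounds can be read off.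

The next member, compound 4, `CN(C)C(=O)c1cc2cnc(Nc3ccc(NC(=O)C4(C(=O)Nc5ccc(Cl)cc5)CC4)cc3)nc2n1C1CCCC1`, differs from compound 2 in one place:

chloro in place of bromo on an aromatic carbon

Halogen for halogen on the same aromatic carbon is a small change in the series; no measured pair shows what such a swap does here, so the expectation rests on the size of the change alone. The step expected from compound 2 to compound 4, a number 4.4 percentage points lower from compound 2 to compound 4 (within the scatter), is small, with no direction that would carry it beyond the scatter.

The estimate for compound 4 in this assay is 92%, expected to fall between 76% and 100%.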

Compound 4, percent growth inhibition at one concentration: 95.7%
Compound 4: middle estimate off by 3.7 percentage points, on the low side; measured number inside the range.
By their numbers in this assay, from the lowest: compounds 1 and 3 (each within the scatter of the next); then compounds 4 and 2 (each within the scatter of the next).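

The series now holds its first step in one place in this assay: a number 0.7 percentage points lower from compound 2 to compound 4 (within the scatter). At this position, on an aromatic carbon of a six-membered aromatic ring of carbon only and para to a large group, 4-chlorophenyl and 4-bromophenyl cannot be told apart on this read-out at the one concentration tested, so the exchange of these two halogens leaves the number within the usual scatter. Nothing measured on these compounds bears on why this is so.

From the compounds shown here alone, whether the position needs a halogen at all stays open, as does what hydrogen, a methoxy group, an amine or a carboxylic acid at the same carbon would do to the number. Fluoro at this position occurs only in compound 1, which also differs from compound 2 and compound 4 elsewhere, so a step for that halogen cannot be read, and a single concentration leaves any difference in potency between compound 2 and compound 4 unresolved.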